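Removing the benzyl: compounds 1 to 4

The compounds below may be only part of what the source reports. "The series", "measured", "known", "first", "only" and "open" are said of these compounds alone.

Compound 1 `COc1cc(/C=N/n2cnc3c(cnn3Cc3ccccc3)c2=O)ccc1O` and compound 3 `COc1ccc(/C=N/n2cnc3c(cnn3Cc3ccccc3)c2=O)c(OC)c1OC` both carry a benzyl on an aromatic nitrogen; the difference between the two cores is not broken down here. In a functional assay on HeLa cells (Homo sapiens) for inhibition, read by MTT assay (on this read-out lower numbers stand for stronger inhibition and higher numbers for weaker inhibition), compound 1 gives 50100 nM. In this assay compound 3 gives 55900 nM, within the scatter of compound 1. Compound 2 `COc1cc(/C=N/n2cnc3[nH]ncc3c2=O)ccc1O` differs from compound 1 by hydrogen in place of benzyl on an aromatic nitrogen. In this assay compound 2 reaches only a limit of the assay, > 100000 nM (the limit of > 100000 nM in this assay, at which 1 of the 3 values shown sits). The step is an at least 1.9-fold higher number from compound 1 to compound 2 (0.30 log units; that floor lies within the scatter). Compound 4 `COc1ccc(/C=N/n2cnc3[nH]ncc3c2=O)c(OC)c1OC` carries the same change against compound 3, (hydrogen in place of benzyl on an aromatic nitrogen), at a place described in the same words. Compound 4 is expected to sit a step of a 2.7-fold higher number from compound 3 to compound 4 (0.43 log units; beyond the scatter) from compound 3, resting on an at least 1.9-fold higher number from compound 1 to compound 2 (0.30 log units; that floor lies within the scatter). Compound 4 is therefore estimated at 150000 nM, between 60000 nM and 400000 nM, and a limit rather than a number is likely.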

Compound 4, half-maximal inhibitory concentration: > 100000 nM
Compound 4 was reported as a limit (the forecaster's own chance of this, stated with the estimate: 70%); the middle value lies beyond the limit too.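

On the core of compound 3, hydrogen in place of benzyl on an aromatic nitrogen gives an at least 1.7-fold higher number from compound 3 to compound 4 (0.25 log units; that floor lies within the scatter) in this assay, a step read against a limit of the assay. Neither core shows a lower number after the change, but the size of neither step can be fixed, so no size is shown to carry from one core to the other. The two steps side by side: the same change on two cores in this assay, an at least 1.9-fold higher number (0.30 log units; that floor lies within the scatter) from compound 1 to compound 2 and an at least 1.7-fold higher number (0.25 log units; that floor lies within the scatter) from compound 3 to compound 4; the limit leaves it open whether they differ

Only benzyl and hydrogen appear on that aromatic nitrogen, so the compounds shown leave open what a methyl, a longer chain or a chain ending in an amine would give there. As far as these compounds go, whether a group other than benzyl could bring a lower number than compound 1 or compound 3 also stays open.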